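This account rests on a few compounds, and the source may have more. Where it says the series, first, only, none or still open, it means among the compounds named here.

Going by the values given here, compound 2 `CC(C)Nc1sc(C(=O)c2ccc(Br)s2)c(N)c1C#N` gives 122 nM in an assay for inhibition of Maternal embryonic leucine zipper kinase (Homo sapiens), read by ADP-Glo, with a stated time of 0.5 h (on this read-out lower numbers stand for stronger inhibition and higher numbers for weaker inhibition), the lower of the two numbers measured so far. Compound 1 `CC(C)Nc1sc(C(=O)c2ccco2)c(N)c1C#N` gives 1350 nM, and the step of an 11-fold lower number from compound 1 to compound 2 (1.04 log units; beyond the scatter) is the only one recorded. Compound 3 `N#Cc1c(NCCCN)sc(C(=O)c2ccc(Br)s2)c1N` differs from compound 2 by 3-aminopropyl in place of isopropyl on a nitrogen on an aromatic ring. That single measured step was made on the carbonyl carbon, not on this nitrogen, so nothing measured bears directly on the present change, and no step beyond the scatter can be predicted in either direction. Compound 3 is therefore expected to show a 1.2-fold higher number from compound 2 to compound 3 (0.09 log units; within the scatter). Compound 3 is estimated at 150 nM, with a range from 50 nM to 500 nM.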

Compound 3, half-maximal inhibitory concentration: 141 nM
Beside the measured number, compound 3's estimate is 1.1-fold (0.03 log units) above it, and the stated range covers the measured number.
By their numbers in this assay, from the lowest: compounds 2 and 3 (each within the scatter of the next); then compound 1.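

In this assay putting 3-aminopropyl in place of isopropyl on a nitrogen on an aromatic ring gives a 1.2-fold higher number from compound 2 to compound 3 (0.06 log units; within the scatter) and so leaves the two compounds indistinguishable. The earlier step concerned only the group on the carbonyl carbon, whereas this one shows that the chain on this nitrogen can carry a terminal amine with no difference beyond the scatter. Nothing available gives a reason for this result. 

From the compounds shown here alone, whether a longer chain or a carboxylic acid at the chain end would also read the same stays open. So does whether a cyclic amine on this nitrogen would.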